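From naphthalen-2-yl to 4-methoxyphenyl on a shared core

The source may hold more compounds than are shown below. What is called first, only, known or untested is meant among the compounds shown, and "the series" means these compounds.

Measured in a functional assay on SK-OV-3 cells (Homo sapiens) for inhibition, read by sulforhodamine B assay, with a stated time of 72 h; a higher number here means a weaker inhibitor, a lower number a stronger inhibitor:
- Compound 1 `COc1ccc(CN(Cc2ccccc2)Cc2c(O)ccc3c(=O)cc(C)oc23)cc1`: 24.6 ug/mL
- Compound 2 `COc1ccc(CN(Cc2ccc3ccccc3c2)Cc2c(O)ccc3c(=O)cc(C)oc23)cc1`: > 100 ug/mL

Compound 2 gives > 100 ug/mL, which is a limit of this assay and not a number. It therefore stands at the limit of > 100 ug/mL in this assay, at which 1 of the 2 values shown sits.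

Compound 3 `COc1ccc(CN(Cc2ccc(OC)cc2)Cc2c(O)ccc3c(=O)cc(C)oc23)cc1` differs from compound 2 by 4-methoxyphenyl in place of naphthalen-2-yl on a saturated chain carbon bound to an amine nitrogen.

Going by the values given here, only one measured step bears on this change: an at least 4.0-fold higher number from compound 1 to compound 2 (0.60 log units; beyond the scatter). There, naphthalen-2-yl entered in place of phenyl at the same place, and the change to compound 3 removes that group again. A step of similar size towards a lower number, beyond the scatter, is therefore expected in this assay, although the limit leaves its true size open. Among the compounds with values here, no measured compound shows what the entering 4-methoxyphenyl does at this place, so the expectation stays broad.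

The expected step is an at least 3.3-fold lower number from compound 2 to compound 3 (0.52 log units; beyond the scatter). For compound 3 the estimated value is 30 ug/mL, with an expected range from 12 ug/mL to 85 ug/mL.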

Compound 3, half-maximal inhibitory concentration: > 100 ug/mL
Compound 3 gave a limit, no number; the forecaster's own chance of this, stated with the estimate: 15%; middle value at least 3.3-fold (0.52 log units) from the limit.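

In this assay compound 3 gives > 100 ug/mL, which is a limit of the assay and not a number, and the step between compound 2 and compound 3 cannot be read. The new information comes from the comparison with compound 1: methoxy in place of hydrogen on an aromatic carbon gives an at least 4.0-fold higher number from compound 1 to compound 3 (0.60 log units; beyond the scatter), so at this place 4-methoxyphenyl, like naphthalen-2-yl, goes with a weaker inhibitor than the phenyl of compound 1, and the weakening does not require a second aromatic ring. Compound 2 and compound 3 cannot be ordered against each other, and all that is known of them here is the shared limit: the limit of > 100 ug/mL in this assay, at which 2 of the 3 values shown sit.

The compounds shown leave open whether the weakening belongs to methoxy in particular or would also appear with a smaller group, such as fluorine or methyl, on that aromatic carbon. They also leave open how far past the limit compound 2 and compound 3 really lie, and whether an amine on that carbon would keep the strength of compound 1.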